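Swapping the (methylsulfanyl)methyl group of compound 3

A few compounds are considered here, and "the series" means these few. Any claim that something is new, unique, unknown or untested is made for them only; others in the source may bear on it.

In a functional assay on HT cells (Homo sapiens) for antiproliferative activity, read by fluorescence, with a stated time of 72 h (on this read-out lower numbers stand for stronger inhibition of growth and higher numbers for weaker inhibition of growth), compound 1 `CC(C)c1n[nH]c2c(NCc3ccc(-c4ccccn4)cc3)nc(SCC(O)CO)nc12` gives 21 nM. Compound 2 `CC(C)c1n[nH]c2c(NCc3ccc(-c4ccccn4)cc3)nc(SCC(O)C(F)(F)F)nc12` gives 690 nM, and compound 3 `CSCCSc1nc(NCc2ccc(-c3ccccn3)cc2)c2[nH]nc(C(C)C)c2n1` gives 975 nM. The set shows a 46-fold higher number from compound 1 to compound 3 (1.67 log units; beyond the scatter) and a 1.4-fold higher number from compound 2 to compound 3 (0.15 log units; within the scatter), so compound 3 sits level with compound 2 and well apart from compound 1.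

Compound 4 `CCC(O)CSc1nc(NCc2ccc(-c3ccccn3)cc2)c2[nH]nc(C(C)C)c2n1` keeps the shared core and alters only the chain: 1-hydroxypropyl in place of (methylsulfanyl)methyl on a saturated chain carbon bound to a sulfur. This places 1-hydroxypropyl in place of (methylsulfanyl)methyl on a saturated chain carbon bound to a sulfur.

The measured steps that bear on this change all concern the same chain. Within the data shown here, the largest gap is the one already seen from compound 3 to compound 1, which carries 1,2-dihydroxyethyl there. The set also shows a 33-fold higher number from compound 1 to compound 2 (1.52 log units; beyond the scatter), where trifluoromethyl stands in place of hydroxymethyl. Compound 2 still bears 2,2,2-trifluoro-1-hydroxyethyl, yet it lies level with compound 3, so a hydroxylated chain alone does not ensure a low number. Compound 4 has neither the hydroxymethyl of compound 1 nor the trifluoromethyl of compound 2, so it is expected to fall between the two levels. The expected change is a 3.9-fold lower number from compound 3 to compound 4 (0.59 log units; beyond the scatter). For compound 4 the estimated value is 250 nM, with an expected range of 70 nM to 800 nM.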

Compound 4, concentration for 50% growth inhibition: 273 nM
The estimate for compound 4 lay 1.1-fold (0.04 log units) below the measured number; measured number inside the range.
By their numbers in this assay, from the lowest: compound 1; then compound 4; then compounds 2 and 3 (each within the scatter of the next).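

In this assay the step of a 3.6-fold lower number from compound 3 to compound 4 (0.55 log units; beyond the scatter) shows that 1-hydroxypropyl on a saturated chain carbon bound to a sulfur improves on (methylsulfanyl)methyl, though it recovers only part of the gap to the 1,2-dihydroxyethyl chain. Two further steps separate the groups around that hydroxy: ethyl in place of trifluoromethyl gives a 2.5-fold lower number from compound 2 to compound 4 (0.40 log units; beyond the scatter) and stays modest, while methyl in place of hydroxy gives a 13-fold higher number from compound 1 to compound 4 (1.11 log units; beyond the scatter) and is large, so a single hydroxy on the chain does not reach the low number of compound 1, and the terminal hydroxy of compound 1 carries the larger share of the difference in these compounds. Nothing given here accounts for these differences.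

The compounds shown leave open whether an amine or a carboxylic acid at the end of the chain could stand in for the terminal hydroxy of compound 1. They also leave open whether a longer chain carrying the same two hydroxy groups would hold the level of compound 1 or fall towards that of compound 4.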